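This account rests on a few compounds, and the source may have more. Where it says the series, first, only, none or still open, it means among the compounds named here.

Measured compounds: compound 1 `CC(C)COC(=O)Nc1ccc([Se]C#N)cc1` gives 21600 nM in an ADME assay on 184B5 cells (Homo sapiens) for cytotoxicity, read by MTT assay, with a stated time of 72 h; on this read-out higher numbers stand for weaker inhibition of growth and lower numbers for stronger inhibition of growth; compound 2 `CCCCCCOC(=O)Nc1ccc([Se]C#N)cc1` gives 20000 nM; compound 3 `N#C[Se]c1ccc(NC(=O)Oc2ccc(F)cc2)cc1` gives 29500 nM.

Compound 3 carries the highest of the three numbers in this assay, yet its gaps to compound 1 and to compound 2 both lie within the scatter, so the three compounds stand level. Compound 4 `N#C[Se]c1ccc(NC(=O)Oc2ccccc2)cc1` differs from compound 3 by hydrogen in place of fluoro on an aromatic carbon. Going by the values given here, the single measured step, a 1.1-fold lower number from compound 1 to compound 2 (0.03 log units; within the scatter), concerns the saturated chain carbon bound to an oxygen next to a carbonyl group, not the aromatic carbon where the fluoro sits, so no measured step bears directly on this change. Without such guidance, no step beyond the scatter is expected in this assay. Compound 4 is therefore estimated to give 26000 nM, between 12000 nM and 55000 nM. This expectation means a step of a 1.1-fold lower number from compound 3 to compound 4 (0.05 log units; within the scatter).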

Compound 4, concentration for total growth inhibition: 22700 nM
Compound 4: the middle estimate sits 1.1-fold (0.06 log units) above what was measured, and the stated range covers the measured number.
By their numbers in this assay, from the lowest: compounds 2, 1, 4 and 3 (each within the scatter of the next).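

In this assay, hydrogen in place of fluoro on the aromatic carbon gives no real change (a 1.3-fold lower number from compound 3 to compound 4 (0.11 log units; within the scatter)), so this position tolerates losing the fluoro. Changing the group on the oxygen also leaves the number level, with phenyl in place of hexyl (a 1.1-fold higher number from compound 2 to compound 4 (0.05 log units; within the scatter)) and phenyl in place of isobutyl (a 1.1-fold higher number from compound 1 to compound 4 (0.02 log units; within the scatter)). No measurement shown explains why these changes stay so small.

As far as these compounds go, whether an amine or a carboxylic acid on that aromatic carbon would move the number beyond the scatter stays open.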